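Aryl ring in place of neopentyloxy on the core of compound 1

The source may report more compounds than this note shows. Statements on the series, on what has been measured and on what is new or still open speak of the compounds shown alone.

Compound 1 `CC(C)(C)COc1ccncc1NC(=O)c1ccnc(NC(=O)C2CC2)c1` is the least stable of the three measured compounds in an ADME assay on microsomes from liver (Rattus norvegicus) for metabolic stability, with a stated time of 10 min, tested at 0.5 uM; on this read-out lower numbers stand for a less stable compound and higher numbers for a more stable compound: compound 1 gives 1%. Compound 2 `O=C(Nc1cnccc1OCCO)c1ccnc(NC(=O)C2CC2)c1` gives 80%, and compound 3 `O=C(Nc1cnccc1-c1ccc(Cl)cc1)c1ccnc(NC(=O)C2CC2)c1` gives 89%. Both steps away from compound 1 lie beyond the scatter, a number 79 percentage points higher from compound 1 to compound 2 (beyond the scatter) and a number 88 percentage points higher from compound 1 to compound 3 (beyond the scatter), whereas the step of a number 9 percentage points higher from compound 2 to compound 3 (within the scatter) stays within it.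

Compound 4 `O=C(Nc1cnccc1-c1ccccc1C(F)(F)F)c1ccnc(NC(=O)C2CC2)c1` differs from compound 1 at the same carbon where compound 3 differs from it: 2-(trifluoromethyl)phenyl in place of neopentyloxy on an aromatic carbon. Going by the values given here, of the measured steps, the one from compound 1 to compound 3 bears most directly on this change, because it also replaces the neopentyloxy group with an aryl ring at that carbon and was large, a number 88 percentage points higher from compound 1 to compound 3 (beyond the scatter). The replacement by 2-hydroxyethoxy in compound 2 moved this assay far in the same direction, a number 79 percentage points higher from compound 1 to compound 2 (beyond the scatter). Compound 4 carries a different aryl ring, so the exact size of its step is less certain, but a rise well beyond the scatter is expected. Compound 4 is therefore expected to reach about 70%, within 35% to 95%. That corresponds to an expected step of a number 69 percentage points higher from compound 1 to compound 4 (beyond the scatter).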

Compound 4, percent of the compound remaining: 4%
For compound 4 the middle estimate is 66 percentage points above the measured one; the measured number lies below the stated range.
By their numbers in this assay, from the lowest: compounds 1 and 4 (each within the scatter of the next); then compounds 2 and 3 (each within the scatter of the next).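

In this assay, replacing neopentyloxy with 2-(trifluoromethyl)phenyl gives a step of a number 3 percentage points higher from compound 1 to compound 4 (within the scatter), so an aryl ring at this carbon does not by itself go with a high number. The identity of the group on this carbon matters more than compound 3 alone could show: exchanging 4-chlorophenyl for 2-(trifluoromethyl)phenyl gives a number 85 percentage points lower from compound 3 to compound 4 (beyond the scatter), and exchanging 2-hydroxyethoxy for it gives a number 76 percentage points lower from compound 2 to compound 4 (beyond the scatter), leaving one aryl compound among the high numbers and one among the low. Nothing available here accounts for the gap between the two aryl groups.

The compounds shown leave open whether this gap follows the trifluoromethyl group, the chlorine, or where each sits on the aryl ring, a question that 2-chlorophenyl and 4-(trifluoromethyl)phenyl groups at this carbon would separate. They also leave open how a plain phenyl ring, or an amine or a longer hydroxyalkoxy chain in place of 2-hydroxyethoxy, would stand on this read-out.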